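Replacing hydroxypyrrolidine with imidazole: an antiproliferative estimate

The source may report more compounds than this note shows. Statements on the series, on what has been measured and on what is new or still open speak of the compounds shown alone.

Compound 1 `COc1cc[nH]c1/C=C1\C(=O)Nc2ccc([N+](=O)[O-])c(N[C@H]3CC[C@H](O)CC3)c21`: 8040 nM in a functional assay on RKO cells (Homo sapiens) for antiproliferative activity, read by MTT assay, with a stated time of 5 days; a lower number here means a stronger inhibitor, a higher number a weaker inhibitor
Compound 2 `COc1cc[nH]c1/C=C1\C(=O)Nc2ccc([N+](=O)[O-])c(N3CCC(O)CC3)c21`: < 10 nM in this assay, a limit of the assay rather than a number.
Compound 3 `COc1cc[nH]c1/C=C1\C(=O)Nc2ccc([N+](=O)[O-])c(N3CC[C@@H](O)C3)c21`: 32 nM in this assay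

The three measured compounds share one core and differ only in the substituent on one aromatic carbon. Among the two plain numbers, compound 3 stands lowest; its nearest neighbour is compound 1, separated by a 250-fold lower number from compound 1 to compound 3 (2.40 log units; beyond the scatter). Compound 2 sits at the limit of the assay. Between the two cyclic amines the gap is an at least 3.2-fold higher number from compound 2 to compound 3 (0.50 log units; beyond the scatter), and the move away from the acyclic amine linkage shows an at least 800-fold lower number from compound 1 to compound 2 (2.90 log units; beyond the scatter).

Compound 4 `COc1cc[nH]c1/C=C1\C(=O)Nc2ccc([N+](=O)[O-])c(-n3ccnc3)c21` brings (1H-imidazol-1-yl in place of 3-hydroxypyrrolidin-1-yl on an aromatic carbon). Going by the values given here, no measured step removes the hydroxyl or exchanges a saturated ring for an aromatic one, so the direction rests on analogy alone: the measured steps show that this position tolerates large swings, while the two ring-nitrogen-linked groups differ only modestly. A higher number is expected for compound 4, roughly a 7.8-fold higher number from compound 3 to compound 4 (0.89 log units; beyond the scatter), giving an estimated 250 nM with a range from 25 nM to 2500 nM.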

Compound 4, half-maximal inhibitory concentration: 3920 nM
The estimate for compound 4 lay 16-fold (1.20 log units) below the measured number, and the stated range ends below it.
By their numbers in this assay, from the lowest: compound 3; then compound 4; then compound 1. At a limit, below all of these: compound 2.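

Compound 4 shows that attachment through a ring nitrogen is not enough to keep a low number at this aromatic carbon: in this assay, 1H-imidazol-1-yl in place of 3-hydroxypyrrolidin-1-yl gives a 120-fold higher number from compound 3 to compound 4 (2.09 log units; beyond the scatter). Against 4-hydroxypiperidin-1-yl the result is an at least 390-fold higher number from compound 2 to compound 4 (2.59 log units; beyond the scatter), a step that rests on a limit and not on a number: the limit of < 10 nM in this assay, at which 1 of the 4 values shown sits. The imidazole also falls far from both saturated rings and much closer to the (4-hydroxycyclohexyl)amino group, with a 2.1-fold lower number from compound 1 to compound 4 (0.31 log units; beyond the scatter).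

This change removes the hydroxyl and the saturated ring together, so the compounds shown cannot tell which of the two accounts for the large step. A plain pyrrolidin-1-yl group, or an imidazole carrying a hydroxymethyl group, would pull these two changes apart.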